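The compounds below may be only part of what the source reports. "The series", "measured", "known", "first", "only" and "open" are said of these compounds alone.

The measured compounds:
Compound 1 `CCOC(=O)c1cnn(-c2nc(-c3cccc(OC)c3OC)c(C#N)c(=O)n2C)c1N` gives 69 ug/mL in a functional assay, with a stated time of 150 min; on this read-out lower numbers stand for stronger inhibition and higher numbers for weaker inhibition.
Compound 2 `CSc1nc(-c2cccs2)c(C#N)c(=O)n1C` gives 87 ug/mL in this assay.
Compound 3 `COc1cccc(-c2nc(NN)n(C)c(=O)c2C#N)c1OC` gives 54 ug/mL in this assay.

These three numbers lie close together. The gap between compound 1 and compound 2 and the gap between compound 1 and compound 3 both fall within the usual scatter of repeated measurements, so none of the three can be called stronger or weaker than another on this evidence. No two of the measured compounds differ in only one place, so no single structural step can be read off directly from them.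

Compound 4 `CCOC(=O)c1cnn(-c2nc(-c3cccc(O)c3O)c(C#N)c(=O)n2C)c1N` has not yet been measured. It differs from compound 1 in one place: 2,3-dihydroxyphenyl in place of 2,3-dimethoxyphenyl on an aromatic carbon. Within the data shown here, with no measured step of this kind to lean on, the expectation rests on the closeness of the three numbers and on the fact that the rest of the molecule is unchanged. Compound 4 is therefore expected to give 50 ug/mL, with a range from 20 ug/mL to 130 ug/mL. This estimate means a step of a 1.4-fold lower number from compound 1 to compound 4 (0.14 log units; within the scatter), expected to stay within the scatter rather than to mark a clear change in either direction.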

Compound 4, half-maximal inhibitory concentration: 58 ug/mL
Compound 4: middle estimate off by 1.2-fold (0.06 log units), on the low side; the range from low to high includes it.
By their numbers in this assay, from the lowest: compounds 3, 4, 1 and 2 (each within the scatter of the next).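

In this assay, among these compounds, placing 2,3-dihydroxyphenyl instead of 2,3-dimethoxyphenyl on this aromatic carbon gives a 1.2-fold lower number from compound 1 to compound 4 (0.08 log units; within the scatter) and is the first comparison in which only one place differs. The entering group has 2 hydrogen-bond donors where the leaving group has 0, and it has fewer heavy atoms, yet the read-out does not separate compound 1 from compound 4. At this position, then, the two groups cannot be told apart in this assay, even though they differ in these counted features. Nothing measured here explains why the two groups read alike.

Compound 3 has 2,3-dimethoxyphenyl but no partner with 2,3-dihydroxyphenyl among the compounds shown, so it remains open whether the same swap would read alike on a different group elsewhere on the core. Also open, from the compounds shown here alone, is how this position would respond to an ethoxy group in place of each methoxy, or to a carboxylic acid or an amine on the phenyl ring.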